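Swapping the Aryl Group of Compound 1 for Pyrimidinyl

A few compounds are considered here, and "the series" means these few. Any claim that something is new, unique, unknown or untested is made for them only; others in the source may bear on it.

Of the compounds shown here, two have been measured in an assay on isolated protein for inhibition of serine/threonine-protein kinase Nek1 (Homo sapiens), read by radiometric assay and 33P incorporation, in the presence of a further agent that is not named here; a lower number here means a stronger inhibitor, a higher number a weaker inhibitor. Compound 1 `COC(=O)c1cccc(-c2cnc3[nH]cc(-c4cccc(OC)c4)c3c2)c1` gives 166 nM in this assay, the lower of the two numbers. Compound 2 `c1ccc(Nc2nccc(Nc3cc(C4CC4)[nH]n3)n2)cc1` gives 850 nM, a higher number that lies beyond the scatter. Compound 3 `COC(=O)c1cccc(-c2cnc3[nH]cc(-c4cncnc4)c3c2)c1` differs from compound 1 in one place: pyrimidin-5-yl in place of 3-methoxyphenyl on an aromatic carbon. Going by the values given here, no measured pair shows this change, so its effect is unknown. Compound 3 is expected to give a somewhat higher number, with the step of a 1.8-fold higher number from compound 1 to compound 3 (0.26 log units; within the scatter) small and possibly within the scatter. The estimate for compound 3 in this assay is 300 nM, within 100 nM to 900 nM.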

Compound 3, half-maximal inhibitory concentration: 62.5 nM
For compound 3 the middle estimate is 4.8-fold (0.68 log units) above the measured one; the measured number lies below the stated range.
By their numbers in this assay, from the lowest: compound 3; then compound 1; then compound 2.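

In this assay this aromatic carbon of the five-membered ring tolerates a change of ring: pyrimidin-5-yl in place of 3-methoxyphenyl gives a 2.7-fold lower number from compound 1 to compound 3 (0.42 log units; beyond the scatter) and so improves on compound 1. The methoxy group and the carbon-only ring are therefore not required for inhibition in this series. Nothing available explains this step.

From the compounds shown here alone, it remains open whether pyridin-3-yl would match pyrimidin-5-yl at this position. Also unresolved is whether a carboxylic acid or an amide in place of the methyl ester would keep the gain.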